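Fluoro at the chloro-bearing position of the hydroxyphenyl amide

The source may hold more compounds than are shown below. What is called first, only, known or untested is meant among the compounds shown, and "the series" means these compounds.

Three compounds share the same core, differing only in the hydroxyphenyl attached to the carbonyl. Compound 1 `O=C(Nc1cc(C(F)(F)F)cc(C(F)(F)F)c1)c1ccccc1O` carries no halogen on that ring; compound 2 `O=C(Nc1cc(C(F)(F)F)cc(C(F)(F)F)c1)c1cccc(Cl)c1O` carries a 3-chloro-2-hydroxyphenyl and compound 3 `O=C(Nc1cc(C(F)(F)F)cc(C(F)(F)F)c1)c1ccc(Cl)cc1O` a 4-chloro-2-hydroxyphenyl. In an assay on cells for antagonist activity at P2X purinoceptor 4 (Homo sapiens), read by fluorescence and calcium flux, with a stated time of 30 min (on this read-out higher numbers stand for weaker inhibition and lower numbers for stronger inhibition), compound 1 gives 155 nM, compound 2 gives 48.8 nM and compound 3 gives 209 nM. Compound 3 thus has the highest of the three numbers, but its separation from compound 1 is within scatter (a 1.3-fold higher number from compound 1 to compound 3 (0.13 log units; within the scatter)), while its separation from compound 2 is clear (a 4.3-fold higher number from compound 2 to compound 3 (0.63 log units; beyond the scatter)).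

Compound 4 `O=C(Nc1cc(C(F)(F)F)cc(C(F)(F)F)c1)c1cccc(F)c1O` is the next step: 3-fluoro-2-hydroxyphenyl in place of 4-chloro-2-hydroxyphenyl on a carbonyl carbon. Among the compounds with values here, two measured steps bear on it. The step of a 3.2-fold lower number from compound 1 to compound 2 (0.50 log units; beyond the scatter) shows that chloro in the 3-chloro-2-hydroxyphenyl arrangement lowers the number, and the step of a 4.3-fold higher number from compound 2 to compound 3 (0.63 log units; beyond the scatter) shows that the 4-chloro-2-hydroxyphenyl arrangement loses that gain. Within the data shown here, compound 4 places fluoro where compound 2 places chloro, but no fluoro analogue has been measured, so the size of its effect is uncertain. A lower number than compound 3 is expected, a step of about a 2.5-fold lower number from compound 3 to compound 4 (0.39 log units; beyond the scatter), probably short of the full gain of compound 2. Compound 4 is therefore estimated at 85 nM, with a likely range of 35 nM to 210 nM.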

Compound 4, half-maximal inhibitory concentration: >= 10000 nM
Compound 4 gave a limit, no number; the forecaster's own chance of this, stated with the estimate: 2%; middle value at least 110-fold (2.07 log units) from the limit.
By their numbers in this assay, from the lowest: compound 2; then compounds 1 and 3 (each within the scatter of the next). At a limit, above all of these: compound 4.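

Compound 4 gives a limit of the assay, not a number: the limit of >= 10000 nM in this assay, at which 1 of the 4 values shown sits. Fluoro in place of chloro on the aromatic carbon gives an at least 200-fold higher number from compound 2 to compound 4 (2.31 log units; beyond the scatter), and fluoro in place of hydrogen gives an at least 64-fold higher number from compound 1 to compound 4 (1.80 log units; beyond the scatter), so at this position the two halogens move the number in opposite directions: chloro lowers it relative to compound 1 and fluoro raises it, and the earlier gain cannot be read as a general halogen effect. The change of 4-chloro-2-hydroxyphenyl to 3-fluoro-2-hydroxyphenyl gives an at least 47-fold higher number from compound 3 to compound 4 (1.67 log units; beyond the scatter), so even the 4-chloro-2-hydroxyphenyl arrangement, which shows no gain over the unsubstituted ring of compound 1, stands far from the 3-fluoro-2-hydroxyphenyl arrangement.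

Still open, on these data alone, is whether bromo, methyl or methoxy at the position of the chloro in compound 2 would follow compound 2 or compound 4, and with only these two substituents there no trend across groups can be drawn. As far as these compounds go, the true size of all three steps also stays open, since each ends at a limit and gives only a lower bound.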